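The source may report more compounds than this note shows. Statements on the series, on what has been measured and on what is new or still open speak of the compounds shown alone.

In a functional assay on A549 cells (Homo sapiens) for cytotoxicity, read by MTT assay, with a stated time of 72 h (a lower number here means a stronger inhibitor, a higher number a weaker inhibitor), three compounds have been measured so far. Compound 1 `S=C=NCCCCSCc1ccccc1` gives 51300 nM, compound 2 `CCCC[S+]([O-])CCCCN=C=S` gives 9560 nM, and compound 3 `[O-][S+](CCCCN=C=S)Cc1ccccc1` gives 7410 nM. Compound 3 thus lies within the scatter of compound 2, and its number is well beneath that of compound 1, beyond the scatter. Compound 4 `O=[N+]([O-])c1ccc(C[S+]([O-])CCCCN=C=S)cc1` departs from compound 3 in one place: nitro in place of hydrogen on an aromatic carbon, with nitro in place of hydrogen on an aromatic carbon. Among the measured compounds shown here, no measured pair shows a change of this kind, so the data offer no direct guide, and no shift beyond the scatter is expected in this assay. The estimated change is small, a 1.2-fold lower number from compound 3 to compound 4 (0.09 log units; within the scatter). For compound 4 the expected value is 6000 nM, within an estimated range of 2500 nM to 15000 nM.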

Compound 4, half-maximal inhibitory concentration: 14400 nM
The estimate for compound 4 lay 2.4-fold (0.38 log units) below the measured number, and the stated range covers the measured number.
By their numbers in this assay, from the lowest: compounds 3, 2 and 4 (each within the scatter of the next); then compound 1.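

In this assay, nitro in place of hydrogen on an aromatic carbon, para to a large group, gives a 1.9-fold higher number from compound 3 to compound 4 (0.29 log units; within the scatter) and so moves the number by no more than the usual scatter. Among the compounds shown here, this is the first measured change on the aromatic ring, and it shows that this position carries a group of three heavy atoms with no shift the assay can distinguish. No measured evidence here bears on why this is so.

The compounds shown leave open whether an amine, a methoxy group or a chlorine atom at this position would shift the number beyond the scatter.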